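A few compounds are considered here, and "the series" means these few. Any claim that something is new, unique, unknown or untested is made for them only; others in the source may bear on it.

Compound 1, `COc1cc(-c2cc(/C=C/C(=O)c3ccc(N)cc3)[nH]n2)cc(OC)c1OC`, and compound 2, `COc1ccc(-c2cc(/C=C/C(=O)c3ccc(N)cc3)[nH]n2)cc1OC`, share a core and differ in one place. In a functional assay on UACC-62 cells (Homo sapiens) for inhibition, read by sulforhodamine B assay, with a stated time of 48 h (on this read-out higher numbers stand for weaker inhibition of growth and lower numbers for stronger inhibition of growth), compound 1 gives 3580 nM, and in the same assay compound 2 gives 10900 nM. The change that separates them, (hydrogen in place of methoxy on an aromatic carbon), produced a 3.0-fold higher number from compound 1 to compound 2 (0.48 log units; beyond the scatter).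

Compound 3, `COc1cc(C(=O)/C=C/c2cc(-c3cc(OC)c(OC)c(OC)c3)n[nH]2)cc(OC)c1OC`, carries the same kind of substitution pattern on a differently arranged core; the difference between the two cores is not broken down here. In this assay compound 3 gives 3680 nM, which places it close to compound 1 and apart from compound 2.

Compound 4, `COc1ccc(-c2cc(/C=C/C(=O)c3cc(OC)c(OC)c(OC)c3)[nH]n2)cc1OC`, has not yet been measured. It stands to compound 3 as compound 2 stands to compound 1: the change is hydrogen in place of methoxy on an aromatic carbon, and the place of the change is described in the same words for both pairs. Within the data shown here, the only guide to its size is the single earlier example, in which the same change gave a 3.0-fold higher number from compound 1 to compound 2 (0.48 log units; beyond the scatter) on the core of compound 1. Among the measured compounds shown here, whether the core of compound 3 answers in the same way is not known, since no second pair is available to test it, and the two cores differ in a way that is not counted.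

On that basis the step to compound 4 is expected to be a 2.7-fold higher number from compound 3 to compound 4 (0.43 log units; beyond the scatter). Compound 4 is therefore estimated to give 10000 nM in this assay, with a range from 4000 nM to 25000 nM expected to cover most repeat measurements.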

Compound 4, concentration for total growth inhibition: 3880 nM
Compound 4: middle estimate off by 2.6-fold (0.41 log units), on the high side; measured number outside the range, below it.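

In this assay, putting hydrogen in place of methoxy on the core of compound 3 gave a 1.1-fold higher number from compound 3 to compound 4 (0.02 log units; within the scatter), so on this core the two numbers cannot be told apart. On the core of compound 1, the same change gave a step beyond the scatter, which shows that in this series the size of the step did not carry over from one core to the other: the same change on two cores in this assay, a 3.0-fold higher number (0.48 log units; beyond the scatter) from compound 1 to compound 2 and a 1.1-fold higher number (0.02 log units; within the scatter) from compound 3 to compound 4, 2.9-fold (0.46 log units) apart, beyond the scatter of two such steps. This does not show which feature of the two cores accounts for the gap or whether either step would hold in another assay, and two pairs are too few to say how the change would behave on any further core.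

The compounds shown leave open whether another group in the same place, such as a hydroxyl, a fluorine or an ethoxy, would also give steps that differ between the two cores. They also leave open which part of the difference between the cores matters, since no pair shown separates the parts of that difference one at a time.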